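Swapping the pyridine attachment point in two related series

This account rests on a few compounds, and the source may have more. Where it says the series, first, only, none or still open, it means among the compounds named here.

Compound 1 `O=C(/C=C/c1cn(-c2ccccc2)nc1-c1cccnc1)c1ccsc1` is tested in a functional assay on HCT-116 cells (Homo sapiens) for inhibition, read by sulforhodamine B assay, with a stated time of 72 h (a higher number here means a weaker inhibitor, a lower number a stronger inhibitor), where compound 1 gives 1300 nM. Compound 3 `O=C(/C=C/c1cn(-c2ccccc2)nc1-c1ccncc1)c1ccsc1` gives 1100 nM in this assay. The change between them, (pyridin-4-yl in place of pyridin-3-yl on an aromatic carbon), produced a 1.2-fold lower number from compound 1 to compound 3 (0.07 log units; within the scatter). Compound 2 `COc1cc(C(=O)/C=C/c2cn(-c3ccccc3)nc2-c2cccnc2)cc(OC)c1OC` has a different core; the difference between the cores of compound 1 and compound 2 is not broken down here. In this assay compound 2 gives 8600 nM, the highest of the three numbers and beyond the scatter from both others. Compound 4 `COc1cc(C(=O)/C=C/c2cn(-c3ccccc3)nc2-c2ccncc2)cc(OC)c1OC` is not yet measured. Its change from compound 2, (pyridin-4-yl in place of pyridin-3-yl on an aromatic carbon), is the same kind of change as the earlier one, though the place is next to the ring atom that bears a large group, where in compound 1 that atom bears a group of 9 heavy atoms. Because a 1.2-fold lower number from compound 1 to compound 3 (0.07 log units; within the scatter) lay within the scatter, the step is expected to be a 1.2-fold lower number from compound 2 to compound 4 (0.08 log units; within the scatter). Compound 4 is therefore estimated at 7200 nM, probably between 3500 nM and 15000 nM.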

Compound 4, half-maximal inhibitory concentration: 300 nM
Estimate against measurement, compound 4: 24-fold (1.38 log units) above; measured number outside the range, below it.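

Putting pyridin-4-yl in place of pyridin-3-yl gave a 29-fold lower number from compound 2 to compound 4 (1.46 log units; beyond the scatter) in this assay and so did not carry over in size from one core to the other: the same change on two cores in this assay, a 1.2-fold lower number (0.07 log units; within the scatter) from compound 1 to compound 3 and a 29-fold lower number (1.46 log units; beyond the scatter) from compound 2 to compound 4, 24-fold (1.38 log units) apart, beyond the scatter of two such steps. A step that is small on the core of compound 1 can therefore be large on the core of compound 2, so in this series the result on one core is a poor guide to the result on the other. This does not show why the two cores differ, and two pairs set no rule for any further core.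

The compounds shown leave open whether a phenyl ring bearing an amine or a carboxylic acid, in the place of the pyridine, would match compound 4 in this assay. They also leave open how the same swap behaves on a third core.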